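Cytotoxicity notes: aryl ether in place of aryl amine

The compounds below may be only part of what the source reports. "The series", "measured", "known", "first", "only" and "open" are said of these compounds alone.

Measured compounds:
compound 1 `COc1ccc(Nc2nc(CS(=O)(=O)c3cccc(Cl)c3)nc3ccsc23)cc1` — 60000 nM
compound 2 `COc1ccc(-c2nc(CSc3ccc(C(F)(F)F)cn3)nc3ccsc23)cn1` — > 50000 nM (a limit of the assay)
compound 3 `COc1ccc(-c2nc(CSc3cccc(Cl)c3Cl)nc3ccsc23)cn1` — > 50000 nM (a limit of the assay)

All three were run in an ADME assay on cells (Homo sapiens) for cytotoxicity, read by resazurin assay, with a stated time of 5 days; a higher number here means that more compound is tolerated, a lower number that less compound is tolerated. Among the compounds with values here, compound 1 gives 60000 nM, the only actual number among the three. For compound 2 the assay returns only a limit, > 50000 nM. Compound 3 likewise stops at a limit, > 50000 nM. Within the data shown here, two of the three results therefore sit on (the limit of > 50000 nM in this assay, at which 2 of the 3 values shown sit), and the one number for compound 1 lies close to that limit. Among the measured compounds shown here, no step between measured compounds is available, so the data do not show how any single change on the core of compound 1 moves tolerance.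

Compound 4 `COc1ccc(Oc2nc(CS(=O)(=O)c3cccc(Cl)c3)nc3ccsc23)cc1` has not yet been measured. Relative to compound 1 the change is 4-methoxyphenoxy in place of (4-methoxyphenyl)amino on an aromatic carbon. Given that compound 1 gives 60000 nM, the expected step is small, no change at the digits printed from compound 1 to compound 4 (within the scatter), within the usual scatter and without a preferred direction. For compound 4 the estimate is 60000 nM, with a range from 25000 nM to 150000 nM, and a fair chance that only a limit is returned.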

Compound 4, half-maximal cytotoxic concentration: > 50000 nM
Compound 4: no number, only a limit; the forecaster's own chance of this, stated with the estimate: 50%; the middle value does not contradict the limit.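

Compound 4 returns only a limit, > 50000 nM, so no step between compound 1 and compound 4 can be read: the limit of > 50000 nM in this assay, at which 3 of the 4 values shown sit.

The compounds shown leave open whether 4-methoxyphenoxy in place of (4-methoxyphenyl)amino changes tolerance at all.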